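The source may report more compounds than this note shows. Statements on the series, on what has been measured and on what is new or still open speak of the compounds shown alone.

In a functional assay on Huh-7 cells (Homo sapiens) for cytotoxicity, with a stated time of 48 h (a lower number here means a stronger inhibitor, a higher number a weaker inhibitor), compound 1 `COc1cc(O)c(C(=O)/C=C/c2ccc(F)cc2)c(OC)c1` gives only a limit, > 20000 nM. Compound 2 `COc1cc(OC)c(C(=O)/C=C/c2ccccc2OC)c(OC)c1` gives 9800 nM. Compound 3 `COc1cc(OC)c(C(=O)/C=C/c2ccccc2SC)c(OC)c1` gives 14100 nM, within the scatter of compound 2. Compound 4 `COc1cccc(/C=C/C(=O)c2c(OC)cc(OC)cc2OC)c1` differs from compound 3 by 3-methoxyphenyl in place of 2-(methylsulfanyl)phenyl on a double-bonded chain carbon bound to a double-bonded chain carbon. Within the data shown here, the one measured step bearing on this is a 1.4-fold higher number from compound 2 to compound 3 (0.16 log units; within the scatter), methylsulfanyl in place of methoxy on an aromatic carbon. Read in reverse, that exchange is part of the present change, and no measured step covers the rest. The expected change is therefore none beyond the scatter, with an estimated 1.3-fold lower number from compound 3 to compound 4 (0.11 log units; within the scatter). Compound 4 is expected at 11000 nM, with an estimated range of 4500 nM to 20000 nM.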

Compound 4, half-maximal inhibitory concentration: 8900 nM
Estimate against measurement, compound 4: 1.2-fold (0.09 log units) above; low and high end bracket the measured number.
By their numbers in this assay, from the lowest: compounds 4, 2 and 3 (each within the scatter of the next). At a limit, above all of these: compound 1.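

In this assay, 3-methoxyphenyl on the double-bonded chain carbon reads the same as 2-(methylsulfanyl)phenyl, with a 1.6-fold lower number from compound 3 to compound 4 (0.20 log units; within the scatter), and the same as 2-methoxyphenyl, with a 1.1-fold lower number from compound 2 to compound 4 (0.04 log units; within the scatter). The exchange of 2-methoxyphenyl for 3-methoxyphenyl therefore adds a second change at this position that stays within the scatter, so compound 2, compound 3 and compound 4 are not separated. Nothing measured here bears on these steps. Still open, going by these compounds, is whether an amine or a carboxylic acid on this phenyl ring would move the number beyond the scatter. Also open, on these data alone, is what 4-methoxyphenyl would give on the same carbon.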